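A few compounds are considered here, and "the series" means these few. Any claim that something is new, unique, unknown or untested is made for them only; others in the source may bear on it.

Of the compounds shown here, three of a shared core have been measured in a functional assay on MKN-45 cells (Homo sapiens) for cytotoxicity, read by MTT assay, with a stated time of 72 h; a lower number here means a stronger inhibitor, a higher number a weaker inhibitor. Compound 1 `CN(C)CCCNc1nc(-c2ccc(NC(=O)Nc3ccc(Cl)cc3)cc2)nc2c(Cl)c(Cl)sc12` gives 1530 nM. Compound 2 `CN(C)CCNc1nc(-c2ccc(NC(=O)Nc3ccccc3)cc2)nc2ccsc12` gives 1120 nM. Compound 3 `CCN(CC)CCCNc1nc(-c2ccc(NC(=O)Nc3ccccc3)cc2)nc2ccsc12` gives 980 nM. On these numbers compound 3 holds the lowest value, yet its separation from compound 2 and from compound 1 lies within the scatter, so no order among the three can be claimed. Within the data shown here, the only single-point step recorded, a 1.1-fold lower number from compound 2 to compound 3 (0.06 log units; within the scatter), likewise changes nothing beyond the scatter.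

Compound 4 `CCN(CC)CCCNc1nc(-c2ccc(NC(=O)Nc3ccc(C)cc3)cc2)nc2ccsc12` has not been measured. It differs from compound 3 by methyl in place of hydrogen on an aromatic carbon. Among the measured compounds shown here, no measured pair isolates this change: compound 1 carries a chloro at the same place but also two further chlorines on its core, so its value and that of compound 3 show only that the combined alterations stay within the scatter. For the measured compounds named here, the one step that is recorded was small, and the present change is a single carbon, so the expected step of a 1.1-fold lower number from compound 3 to compound 4 (0.04 log units; within the scatter) is none beyond the scatter. Compound 4 is therefore expected to give about 900 nM, with a likely range from 400 nM to 2000 nM.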

Compound 4, half-maximal inhibitory concentration: 1760 nM
Compound 4: middle estimate off by 2.0-fold (0.29 log units), on the low side, within the range that was stated.
By their numbers in this assay, from the lowest: compounds 3, 2, 1 and 4 (each within the scatter of the next).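

Among these compounds, compound 4 gives the first reading of a single change on the outer ring of the urea, phenyl to 4-methylphenyl. Compound 1 does not supply this reading, as its chloro there comes with two further chlorines on its core and a different amine. In this assay the methyl, placed para to a large group, moves the number by a 1.8-fold higher number from compound 3 to compound 4 (0.25 log units; within the scatter), so this position has so far shown no effect beyond the scatter, and set against a 1.1-fold lower number from compound 2 to compound 3 (0.06 log units; within the scatter) at the amine end of the molecule, neither single change yet separates two compounds. Nothing measured on these compounds offers an explanation for the direction of the methyl step, and with the step inside the scatter there is little here to explain.

From the compounds shown here alone, what remains open is whether a chloro alone at this place, apart from the chlorines on the core of compound 1, or a methoxy, trifluoromethyl or fluoro group there, would move the number beyond the scatter. Also open, going by these compounds, is whether the methyl step would read the same with the dimethylamino chain of compound 2.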